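The source may hold more compounds than are shown below. What is called first, only, known or untested is meant among the compounds shown, and "the series" means these compounds.

Measured in a functional assay on cells (Panel renal (Carcinoma cell lines), Homo sapiens) for inhibition; on this read-out lower numbers stand for stronger inhibition of growth and higher numbers for weaker inhibition of growth:
Compound 1 `CN1C/C(=C\c2cccs2)C(O)/C(=C/c2cccs2)C1`: > 100000 nM
Compound 2 `CN1C/C(=C\c2cccs2)C2=NN(C)C(c3cccs3)C2C1`: > 100000 nM
Compound 3 `Cc1ccc(/C=C2\CN(C)CC3=C2OC(N)=C(C#N)C3c2ccc(C)cc2)cc1`: 54500 nM

The reading of compound 2, > 100000 nM, is a limit of the assay and not a number. Compound 1 also gives only a limit, > 100000 nM. The set therefore gathers at the limit of > 100000 nM in this assay, at which 2 of the 3 values shown sit. Compound 3 alone gives a number, 54500 nM.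

Compound 4 `CN1C/C(=C\c2cccs2)C2=NN(c3ccccc3)C(c3cccs3)C2C1` has not yet been measured in this assay. It keeps the core of compound 2 but has phenyl in place of methyl on an amine nitrogen in a ring. Going by the values given here, no measured pair in this set shows a comparable change, so any expectation rests on thin ground. Starting from a limit, a modest move towards stronger inhibition of growth is expected, though compound 4 may well stay at the limit too. Among the compounds with values here, the only number so far, 54500 nM for compound 3, serves as a rough guide to where a readable value might fall. The expected change is an at least 1.4-fold lower number from compound 2 to compound 4 (0.15 log units; that floor lies within the scatter). For compound 4 the estimated value is 70000 nM. The expected range for this compound runs from 30000 nM to 100000 nM.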

Compound 4, concentration for total growth inhibition: > 100000 nM
Compound 4 gave a limit, no number; the forecaster's own chance of this, stated with the estimate: 55%; middle value at least 1.4-fold (0.15 log units) away from the limit.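

In this assay compound 4 gives > 100000 nM, which is a limit of the assay and not a number. Compound 2 also gives only a limit, so no step can be read between compound 2 and compound 4. The compounds shown leave open whether phenyl in place of methyl on an amine nitrogen in a ring changes inhibition of growth at all. The set stays gathered at one point: the limit of > 100000 nM in this assay, at which 3 of the 4 values shown sit.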